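The source may report more compounds than this note shows. Statements on the series, on what has been measured and on what is new or still open speak of the compounds shown alone.

Compounds measured so far in a functional assay on HEK293 cells for positive allosteric modulation of metabotropic glutamate receptor 5 (Homo sapiens), read by FLIPR and calcium flux; on this read-out higher numbers stand for an effect only at larger amounts of compound and lower numbers for an effect already at smaller amounts:

compound 1 `O=C(COCc1ccccc1)N1CCN(c2ccccc2)CC1`: 7100 nM
compound 2 `O=C(COCc1ccccc1)N1CCN(c2ccccc2Cl)CC1`: 1100 nM
compound 3 `O=C(COCc1ccccc1)N1CCN(c2ccc(Cl)cc2)CC1`: 350 nM

Compound 1 gives the highest number of the three; compound 2 comes nearest to it, and compound 3 lies furthest from it. The new compound 4 `O=C(COCc1ccccc1)N1CCN(c2ccc(F)cc2Cl)CC1` differs from compound 1 in one place: 2-chloro-4-fluorophenyl in place of phenyl on an amine nitrogen in a ring. For the measured compounds named here, two measured steps bear on this change, since each of them also puts a chloro in place of a hydrogen on the same ring. The step of a 6.5-fold lower number from compound 1 to compound 2 (0.81 log units; beyond the scatter) is modest, and the step of a 20-fold lower number from compound 1 to compound 3 (1.31 log units; beyond the scatter) is large; between the two chloro compounds the step of a 3.1-fold lower number from compound 2 to compound 3 (0.50 log units; beyond the scatter) is again modest. Compound 4 carries the chloro of compound 2 and adds a fluorine where compound 3 carries its chloro. A step downward in this assay that at least matches the step to compound 2, and that may approach the step to compound 3, is therefore expected. For compound 4 the estimate is 350 nM, with a range from 100 nM to 1200 nM. This estimate means an expected step of a 20-fold lower number from compound 1 to compound 4 (1.31 log units; beyond the scatter).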

Compound 4, half-maximal effective concentration: 270 nM
Beside the measured number, compound 4's estimate is 1.3-fold (0.11 log units) above it; the range from low to high includes it.
By their numbers in this assay, from the lowest: compounds 4 and 3 (each within the scatter of the next); then compound 2; then compound 1.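

In this assay a fluoro added to the 2-chlorophenyl ring of compound 2 still matters, giving a 4.1-fold lower number from compound 2 to compound 4 (0.61 log units; beyond the scatter) as the first view of a second halogen on this ring. Overall the 2-chloro-4-fluorophenyl group gives a 26-fold lower number from compound 1 to compound 4 (1.42 log units; beyond the scatter) on the amine nitrogen, while its exchange for the 4-chlorophenyl group gives a 1.3-fold lower number from compound 3 to compound 4 (0.11 log units; within the scatter) and so leaves those two rings indistinguishable in this read-out. Nothing available explains the effect of either halogen on this ring.

The compounds shown leave open what a fluoro alone would do on the phenyl ring of compound 1, and whether a methoxy or a trifluoromethyl group in place of the fluoro would give a similar number. From the compounds shown here alone, all four compounds share the rest of the core, so whether these ring effects hold with a different group there also remains open.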